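Aspirin ester half-life: lengthening the acyl chain

This account rests on a few compounds, and the source may have more. Where it says the series, first, only, none or still open, it means among the compounds named here.

Measured compounds:
compound 1 `CC(=O)Oc1ccccc1C(=O)O[C@H]1CO[C@H]2[C@@H]1OC[C@H]2O`: 0.0183 h
compound 2 `CC(=O)Oc1ccccc1C(=O)O[C@H]1CO[C@H]2[C@@H]1OC[C@H]2OC(=O)c1ccc(O)cc1`: 0.0198 h
compound 3 `CCC(=O)O[C@@H]1CO[C@H]2[C@@H]1OC[C@@H]2OC(=O)c1ccccc1OC(C)=O`: 0.011 h

The three compounds were run in an ADME assay on a cell-free system (plasma, Homo sapiens) for metabolic stability, with Plasma (Rattus norvegicus) as the target, read by HPLC, at pH 7.4; a higher number here means that the compound lasts longer, a lower number that the compound disappears faster. Compound 1 sits second highest of the three; compound 2 lies nearest to it, and the two values are within the scatter, a 1.1-fold higher number from compound 1 to compound 2 (0.03 log units; within the scatter). Compound 3 lies furthest from compound 1, yet still within the scatter, a 1.7-fold lower number from compound 1 to compound 3 (0.22 log units; within the scatter). The comparison of compound 2 with compound 3 is likewise within the scatter, a 1.8-fold lower number from compound 2 to compound 3 (0.26 log units; within the scatter).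

Compound 4 `CCCCC(=O)O[C@@H]1CO[C@H]2[C@@H]1OC[C@@H]2OC(=O)c1ccccc1OC(C)=O` has not yet been measured. It differs from compound 1 in one place: butylcarbonyl in place of hydrogen on an oxygen on a saturated carbon. The measured step that bears on this is the one in which propanoyl replaced hydrogen at the same position, giving compound 3: a small downward step within the scatter. The step to compound 2, where an aryl carbonyl entered at that position, left the number essentially unchanged. Neither step suggests that an acyl group at this oxygen moves the half-life beyond the scatter, so a step within the scatter, if anything slightly downward, is expected in this assay, a 1.5-fold lower number from compound 1 to compound 4 (0.18 log units; within the scatter).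

On that basis the half-life of compound 4 is estimated at 0.012 h, within the range 0.006 h to 0.025 h.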

Compound 4, half-life: 0.0117 h
Compound 4: the middle estimate sits 1.0-fold (0.01 log units) above what was measured; the range from low to high includes it.
By their numbers in this assay, from the lowest: compounds 3, 4, 1 and 2 (each within the scatter of the next).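

In this assay, butylcarbonyl on an oxygen on a saturated carbon gives a step that stays within the scatter (a 1.6-fold lower number from compound 1 to compound 4 (0.19 log units; within the scatter)), so a third acyl group at this oxygen joins propanoyl and (4-hydroxyphenyl)carbonyl in leaving the half-life indistinguishable from that of the compound with the free hydroxy. The chain can also be extended from propanoyl to butylcarbonyl without a step beyond the scatter (a 1.1-fold higher number from compound 3 to compound 4 (0.03 log units; within the scatter)), and butyl can stand in place of 4-hydroxyphenyl on the carbonyl carbon with the same outcome (a 1.7-fold lower number from compound 2 to compound 4 (0.23 log units; within the scatter)), so across these four compounds neither the length of this chain nor the choice between a chain and an aryl group separates the half-lives. No measurement shown here accounts for why the half-lives of these compounds stay so close together.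

The compounds shown leave open whether a longer chain than butylcarbonyl, or an acyl group carrying an amine or a carboxylic acid, would also stay within the scatter at this oxygen. They also leave open what an ether or a carbamate at this oxygen, in place of the simple ester, would do to the half-life.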